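The source may hold more compounds than are shown below. What is called first, only, known or untested is meant among the compounds shown, and "the series" means these compounds.

Measured compounds, read out in a functional assay on the whole organism with Mus musculus as the target, in the maximal electroshock model, with a stated time of 45 min; on this read-out higher numbers stand for an effect only at larger amounts of compound and lower numbers for an effect already at smaller amounts:

Compound 1 `COc1cc2c(cc1OC)C(c1ccc(Br)cc1)=NNC(=O)C2`: 123 umol/kg
Compound 2 `COc1cc2c(cc1OC)C(c1ccc(C#N)cc1)=NNC(=O)C2`: > 150 umol/kg, a limit
Compound 3 `COc1cc2c(cc1OC)C(c1cccc([N+](=O)[O-])c1)=NNC(=O)C2`: > 150 umol/kg, a limit

Compound 2 gives no number, only a limit: the limit of > 150 umol/kg in this assay, at which 2 of the 3 values shown sit. Compound 4 `COc1cc2c(cc1OC)C(c1ccc(N)cc1)=NNC(=O)C2` changes one group of compound 2: amino in place of cyano on an aromatic carbon. For the measured compounds named here, the one measured step that touches this group is an at least 1.2-fold higher number from compound 1 to compound 2 (0.08 log units; that floor lies within the scatter), with cyano in place of bromo on an aromatic carbon. That step gives only a floor and involves no amino group, so it cannot size the new change. Compound 1 does reach a number in this assay, at 123 umol/kg. A move towards lower numbers is expected, though with wide uncertainty. The estimated step is an at least 1.8-fold lower number from compound 2 to compound 4 (0.27 log units; that floor lies within the scatter). For compound 4 the expected value is 80 umol/kg, with an estimated range from 30 umol/kg to 170 umol/kg.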

Compound 4, dose for half-maximal effect: 15.9 umol/kg
Compound 4: middle estimate off by 5.0-fold (0.70 log units), on the high side, and the stated range ends above it.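

In this assay, for the compounds shown here, the group on the aromatic carbon para to a large group now proves able to shift the read-out well beyond the scatter, which the earlier compounds did not show at this place. Amino in place of cyano gives an at least 9.4-fold lower number from compound 2 to compound 4 (0.97 log units; beyond the scatter), and amino in place of bromo gives a 7.7-fold lower number from compound 1 to compound 4 (0.89 log units; beyond the scatter), so of the three groups compared here, amino is the one that stands apart. The first of these steps remains a floor rather than a size, since compound 2 carries only a limit: the limit of > 150 umol/kg in this assay, at which 2 of the 4 values shown sit.

The compounds shown leave open how a hydroxyl, a dimethylamino group or an acetamido group would read at this place. They also leave open whether amino would give a similar step at another place on the ring.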